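This account rests on a few compounds, and the source may have more. Where it says the series, first, only, none or still open, it means among the compounds named here.

Measured compounds:
- compound 1, `CC(C)[C@H](C(=O)Nc1ccc(F)cn1)c1ccc(Cl)cc1`: 93%
- compound 2, `CC(C)C(C(=O)Nc1ncccn1)c1ccc(Cl)cc1`: 50%
- compound 3, `CC(C)[C@H](C(=O)Nc1nnc(C(F)(F)F)s1)c1ccc(Cl)cc1`: 115%

All three were tested in a functional assay on CHO cells for agonist activity at Free fatty acid receptor 2 (Homo sapiens), read by cAMP accumulation; on this read-out higher numbers stand for larger maximal responses and lower numbers for smaller maximal responses. Compound 1 gives 93% and stands second highest of the three numbers. Its nearest neighbour on this scale is compound 3, which at 115% lies higher by an amount beyond the scatter; the furthest is compound 2, which at 50% lies lower, again beyond the scatter. No pair of these compounds differs in only one place, so the gaps show only what the two values show.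

The unmeasured compound 4, `CC(C)[C@H](C(=O)NC1=NC(=O)CS1)c1ccc(Cl)cc1`, is compared to compound 1. The change is a group of 6 heavy atoms (3 carbon, 1 nitrogen, 1 oxygen, 1 sulfur; one five-membered non-aromatic ring with 2 hetero atoms) in place of a group of 7 heavy atoms (5 carbon, 1 nitrogen, 1 fluorine; one six-membered aromatic ring with 1 hetero atom), on an amide-type nitrogen. The new group on the amide-type nitrogen differs from the group it replaces in being a five-membered non-aromatic ring with two hetero atoms and two hydrogen-bond acceptors, while the compound keeps the rest of the structure of compound 1.

Within the data shown here, with no single-place step among the measured compounds to lean on, only a modest step is expected, and the expected direction is downward: the estimated step of a number 13 percentage points lower from compound 1 to compound 4 (beyond the scatter) is thought to stay near the edge of the scatter. Compound 4 is therefore estimated at 80% in this assay, in a range from 40% to 115%.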

Compound 4, largest response reached (reported as efficacy), in percent of the reference or control that the assay uses: 96%
Beside the measured number, compound 4's estimate is 16 percentage points below it; the range from low to high includes it.
By their numbers in this assay, from the lowest: compound 2; then compounds 1 and 4 (each within the scatter of the next); then compound 3.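

Among these compounds, the step of a number 3 percentage points higher from compound 1 to compound 4 (within the scatter) in this assay gives the first comparison in which only one place changes, here the group on the amide-type nitrogen. The two compounds cannot be told apart on this read-out, even though the 5-fluoropyridin-2-yl group, a six-membered aromatic ring, gives way to a five-membered non-aromatic ring with 2 hetero atoms and a different count of hydrogen-bond acceptors. For this pair, then, an aromatic ring on the amide-type nitrogen is not needed for the maximal response to stay within the scatter, although this rests on a single step and says nothing about why the two match, a question on which no supporting measurement is available.

Still open, on these data alone, is whether the carbonyl or the sulfur of the new ring matters to the response, and whether a ring is needed at all, as an acetyl group or a plain cyclohexyl ring on the amide-type nitrogen might show. As far as these compounds go, it is equally open how a carboxylic acid or an amine carried on that five-membered ring would read in this assay, and whether such a group would leave the maximal response where it stands.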